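Shortening the alkyl group at the fused ring

A few compounds are considered here, and "the series" means these few. Any claim that something is new, unique, unknown or untested is made for them only; others in the source may bear on it.

Measured so far in a functional assay on SNU-387 cells (Homo sapiens) for antiproliferative activity, read by MTT assay, with a stated time of 72 h; a lower number here means a stronger inhibitor, a higher number a weaker inhibitor:
- compound 1 `COc1cccc(CNCc2c(C(=O)O)n(Cc3ccccc3)c3cc(C(C)C)ccc23)c1`: 5090 nM
- compound 2 `COc1ccc(Cn2c(C(=O)O)c(CNCc3cccc(O)c3)c3ccc(C(C)C)cc32)cc1`: 6860 nM
- compound 3 `COc1cccc(CNCc2c(C(=O)O)n(Cc3ccc(C)cc3)c3cc(C(C)C)ccc23)c1`: 5470 nM

The three measured compounds sit close together. Compound 2 gives the highest of the three numbers in this assay, but its gaps to compound 3 and to compound 1 are both within the scatter, so no order among them can be read.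

Compound 4 `COc1ccc(Cn2c(C(=O)O)c(CNCc3cccc(O)c3)c3ccc(C)cc32)cc1` is not yet measured. It differs from compound 2 in one place: methyl in place of isopropyl on an aromatic carbon. Within the data shown here, the only measured step, a 1.1-fold higher number from compound 1 to compound 3 (0.03 log units; within the scatter), concerns a different ring and a different change, and it stayed within the scatter. Among the measured compounds shown here, no measured pair speaks to exchanging isopropyl for methyl on the fused core, so nothing in the data points to a direction.

Compound 4 is therefore expected to stay near compound 2, with the step of a 1.2-fold higher number from compound 2 to compound 4 (0.07 log units; within the scatter) estimated as a small drift. The estimate for compound 4 is 8000 nM, in a range from 3500 nM to 18000 nM.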

Compound 4, half-maximal inhibitory concentration: 9910 nM
Beside the measured number, compound 4's estimate is 1.2-fold (0.09 log units) below it; measured number inside the range.
By their numbers in this assay, from the lowest: compounds 1, 3, 2 and 4 (each within the scatter of the next).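

In this assay, among these compounds, the exchange of isopropyl for methyl on the aromatic carbon of the fused system gives a 1.4-fold higher number from compound 2 to compound 4 (0.16 log units; within the scatter) as the first step that reads on this position. With 3 heavy atoms leaving and 1 entering, the size of this alkyl group produces no difference that can be read here, so isopropyl and methyl cannot be told apart at this place on the background of compound 2. Nothing available gives a reason for the size of this step.

From the compounds shown here alone, whether a longer chain such as n-butyl, a bulkier tert-butyl group or an amine on this carbon would give a step beyond the scatter remains open. Among the compounds shown here, it also remains open whether the same exchange behaves alike on the background of compound 1 or compound 3, since only one pair speaks to this position.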